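Adding a Bromine to Compound 2: Expected Effect on Cytotoxicity

This account rests on a few compounds, and the source may have more. Where it says the series, first, only, none or still open, it means among the compounds named here.

Compound 1 `O=C(CSc1ncccn1)N1N=C(c2cc3ccccc3oc2=O)C[C@@H]1c1ccc(C(F)(F)F)cc1`: 4750 nM
Compound 2 `CC1=NN(C(=O)CSc2ccccc2)[C@@H](c2cc(Br)cc(Br)c2O)C1`: 10400 nM
Compound 3 `O=C(CSCc1ccco1)N1N=C(c2cc3ccccc3oc2=O)C[C@@H]1c1ccc(C(F)(F)F)cc1`: 11200 nM

These three compounds were tested in a functional assay on HepG2 cells (Homo sapiens) for cytotoxicity, read by MTT assay, with a stated time of 48 h; a lower number here means a stronger inhibitor, a higher number a weaker inhibitor. Compound 2 holds the second highest of the three numbers; its value and that of compound 3 lie within the usual scatter of each other, while compound 1 gives a lower number that lies beyond it. Compound 4 `CC1=NN(C(=O)CSc2ccc(Br)cc2)[C@@H](c2cc(Br)cc(Br)c2O)C1` differs from compound 2 by a single change: bromo in place of hydrogen on an aromatic carbon. Within the data shown here, the only measured step, a 2.4-fold higher number from compound 1 to compound 3 (0.37 log units; beyond the scatter), concerns a different change on a different pair, so no measured step bears directly on this one. Compound 4 is therefore expected to stay close to its parent, at an estimated 8500 nM, with a range of 3500 nM to 20000 nM. The step expected here, a 1.2-fold lower number from compound 2 to compound 4 (0.09 log units; within the scatter), is small and may well fall within the scatter.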

Compound 4, half-maximal inhibitory concentration: 6870 nM
Estimate against measurement, compound 4: 1.2-fold (0.09 log units) above; the measured number falls inside the stated range.
By their numbers in this assay, from the lowest: compounds 1, 4, 2 and 3 (each within the scatter of the next, the first and the last beyond it).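

Among these compounds, this is the first measured step on the phenylsulfanyl group: in this assay, bromo in place of hydrogen gives a 1.5-fold lower number from compound 2 to compound 4 (0.18 log units; within the scatter) and stays within the scatter. At this place, para to a large group, the phenyl ring of compound 2 therefore takes a bromine with no clear shift in the number. Nothing measured here offers an explanation for this result.

From the compounds shown here alone, whether a fluoro, a methoxy or an amine at the same carbon would also leave the number within the scatter remains open.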